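Compound 1 and a methoxy on the fused ring

The compounds below may be only part of what the source reports. "The series", "measured", "known", "first", "only" and "open" are said of these compounds alone.

Measured in a functional assay on MCF7 cells (Homo sapiens) for inhibition, read by MTT assay, with a stated time of 24 h; a higher number here means a weaker inhibitor of growth, a lower number a stronger inhibitor of growth
compound 1 `Cn1cc(-c2nc3ccccc3n2C(=O)c2ccccc2)c2ccccc21` gives 43700 nM
compound 2 `COc1ccc(C(=O)n2c(-c3cn(C)c4ccccc34)nc3ccccc32)cc1OC` gives 10200 nM
compound 3 `Cn1cc(-c2nc3ccccc3n2C(=O)c2cccc(Br)c2)c2ccccc21` gives 63400 nM

Compound 1 stands in the upper pair of the three numbers, and a 1.5-fold higher number from compound 1 to compound 3 (0.16 log units; within the scatter) stays within the scatter. Compound 4 `COc1ccc2c(c1)c(-c1nc3ccccc3n1C(=O)c1ccccc1)cn2C` carries methoxy in place of hydrogen on an aromatic carbon. Going by the values given here, no measured step touches that ring. The nearest guide is a 4.3-fold lower number from compound 1 to compound 2 (0.63 log units; beyond the scatter), where 3,4-dimethoxyphenyl replaces phenyl on a carbonyl carbon, a different place from the change in compound 4. That guide is weak, so only a small drop in this assay is expected, namely a 1.5-fold lower number from compound 1 to compound 4 (0.16 log units; within the scatter) as the estimated step. The estimate for compound 4 is 30000 nM (expected range 13000 nM to 65000 nM).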

Compound 4, concentration for 50% growth inhibition: 38400 nM
The estimate for compound 4 lay 1.3-fold (0.11 log units) below the measured number; the measured number falls inside the stated range.
By their numbers in this assay, from the lowest: compound 2; then compounds 4, 1 and 3 (each within the scatter of the next).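

In this assay methoxy in place of hydrogen on this aromatic carbon gives a 1.1-fold lower number from compound 1 to compound 4 (0.06 log units; within the scatter) and so stays within the scatter. The ring carrying the methyl-substituted nitrogen therefore accepts this group without a readable shift in growth inhibition, whereas the carbonyl aryl change gives a 4.3-fold lower number from compound 1 to compound 2 (0.63 log units; beyond the scatter) and lies beyond the scatter. No supporting measurement bears on why this step is so small.

An amine or a carboxylic acid on this carbon could still read differently from methoxy. As far as these compounds go, whether methoxy here adds anything alongside the 3,4-dimethoxyphenyl on the carbonyl carbon also remains open.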